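Swapping the alkyne-linked ring toward a chlorophenyl end group

The source may hold more compounds than are shown below. What is called first, only, known or untested is meant among the compounds shown, and "the series" means these compounds.

Measured so far:
compound 1 `COc1ccccc1C#Cc1cc(Cl)ccc1OCC(=O)O`: 190 nM
compound 2 `Cn1ccnc1C#Cc1cc(Cl)ccc1OCC(=O)O`: 1470 nM

In an assay on CHO cells for displacement of a labelled ligand from prostaglandin D2 receptor 2 (Homo sapiens), read by scintillation counting (a lower number here means a stronger inhibitor, a higher number a weaker inhibitor), compound 2 gives 1470 nM, the higher of the two numbers measured, so it is the weaker inhibitor. Compound 1, which carries a 2-methoxyphenyl group on the same triple-bonded carbon, gives 190 nM in this assay, a clearly lower number. Compound 3 `O=C(O)COc1ccc(Cl)cc1C#Cc1ccc(Cl)cc1` has not yet been measured. It differs from compound 2 in one place: 4-chlorophenyl in place of 1-methyl-1H-imidazol-2-yl on a triple-bonded carbon. The entering group is an all-carbon aromatic ring, which makes compound 3 closer in kind to compound 1 than to compound 2. On this basis, the change is expected to move the number in this assay downward, toward a stronger inhibitor, by roughly a 9.8-fold lower number from compound 2 to compound 3 (0.99 log units; beyond the scatter). The estimate for compound 3 in this assay is therefore 150 nM, with a plausible range from 40 nM to 600 nM.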

Compound 3, inhibition constant: 60 nM
Compound 3: middle estimate off by 2.5-fold (0.40 log units), on the high side, and the stated range covers the measured number.
By their numbers in this assay, from the lowest: compound 3; then compound 1; then compound 2.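

In this assay the end group on the triple-bonded carbon has a strong say: 4-chlorophenyl in place of 1-methyl-1H-imidazol-2-yl gives a 25-fold lower number from compound 2 to compound 3 (1.39 log units; beyond the scatter) and that step is large. Compound 1 and compound 2 had already shown that this position responds to a change of group, and now a second all-carbon ring, the 4-chlorophenyl of compound 3, gives 60 nM and so the lowest number of the three, with compound 1 at 190 nM in between. Nothing available explains the size of this step.

From the compounds shown here alone, whether the chlorine on the end ring matters, or the carbon-only ring alone is enough, remains open: a plain phenyl or a 4-fluorophenyl end group would test this. How far the position tolerates a ring with one nitrogen, such as a pyridine, is also unknown.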